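The source may hold more compounds than are shown below. What is called first, only, known or untested is meant among the compounds shown, and "the series" means these compounds.

Thiourea series built on the core of compound 1, `Oc1ccccc1NC(=S)Nc1ccc2[nH]ccc2c1`. In an ADME assay on cells for inhibition of Amine oxidase [flavin-containing] A (Homo sapiens), read by spectrophotometry (a higher number here means a weaker inhibitor, a lower number a stronger inhibitor), compound 1 gives 39000 nM. Compound 2, `Oc1cccc(NC(=S)Nc2ccc3[nH]ccc3c2)c1`, is reported in this assay as "not active" (no number reported). Compound 3, `Cc1ccc(NC(=S)Nc2ccc3[nH]ccc3c2)c(O)c1`, also stands without a number in this assay, reported as "not active" (no number reported), so both hydroxy-bearing analogues apart from compound 1 lie outside the measurable range, and compound 3 sits at the weak end of what is known. The next analogue, compound 4, `Oc1cc(Cl)ccc1NC(=S)Nc1ccc2[nH]ccc2c1`, carries chloro in place of methyl on an aromatic carbon. Going by the values given here, no measured step covers this change. With compound 3 inactive and compound 1 weak, inhibition for compound 4 is expected to remain weak, and a result of no number is almost as likely as a value. Compound 4 is estimated at 45000 nM, expected between 12000 nM and 180000 nM.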

Compound 4, half-maximal inhibitory concentration: 39000 nM
Beside the measured number, compound 4's estimate is 1.2-fold (0.06 log units) above it, and the stated range covers the measured number.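

In this assay, adding chloro gives no change at the digits printed from compound 1 to compound 4 (within the scatter), so this position holds chloro with the reading kept. With methyl at the same place, compound 3 is reported as "not active". Compound 4 gives 39000 nM. Nothing at hand explains this contrast.

Open, from the compounds shown here alone, is whether a methoxy group or an amine at this place would keep a measurable reading. Also open, going by these compounds, is whether any group here would shift the value away from that of compound 1.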